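A few compounds are considered here, and "the series" means these few. Any claim that something is new, unique, unknown or untested is made for them only; others in the source may bear on it.

Measured in a functional assay on a cell-free system (plasma, Homo sapiens), with a stated time of 3 min; on this read-out lower numbers stand for stronger inhibition and higher numbers for weaker inhibition:
- compound 1 `O=C(NCc1cc(Cl)ccc1-n1cnnn1)[C@@H]1C[C@@H]2C[C@@H]2N1C(=O)[C@H](O)C1CCCCC1`: 600 nM
- compound 2 `O=C(NCc1cc(Cl)ccc1-n1cnnn1)[C@@H]1[C@H]2C[C@H]2CN1C(=O)[C@H](O)Cn1cccn1`: 1800 nM

Compound 1, at 600 nM, holds the lower of the two numbers in this assay. The gap to compound 2, at 1800 nM, lies beyond the usual scatter. These two compounds differ in more than one place, so no measured single change is available as a guide.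

Compound 3 `CC(C)(C)C[C@@H](O)C(=O)N1[C@H](C(=O)NCc2cc(Cl)ccc2-n2cnnn2)C[C@@H]2C[C@@H]21` is still to be measured. It has neopentyl in place of cyclohexyl on a saturated chain carbon bound to a carbonyl carbon and an oxygen on a saturated carbon. The shared core stays unchanged. For the measured compounds named here, with no measured step to draw on, no clear direction is expected, and the estimated step of a 1.2-fold higher number from compound 1 to compound 3 (0.07 log units; within the scatter) is expected to stay within the scatter. For compound 3 the expected value is 700 nM, with an estimated range of 220 nM to 2200 nM.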

Compound 3, half-maximal inhibitory concentration: 570 nM
Compound 3: the middle estimate sits 1.2-fold (0.09 log units) above what was measured; the measured number falls inside the stated range.
By their numbers in this assay, from the lowest: compounds 3 and 1 (each within the scatter of the next); then compound 2.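

In this assay, for the compounds shown here, neopentyl in place of cyclohexyl on a saturated chain carbon bound to a carbonyl carbon and an oxygen on a saturated carbon gives a 1.1-fold lower number from compound 1 to compound 3 (0.02 log units; within the scatter), the first single change that can be read. For this pair, an open chain without a ring serves in place of the six-membered carbon ring with no difference beyond the scatter, so the ring is not needed to keep the number on the shared core of compound 1. No measured evidence bears on why the two groups read alike.

Going by these compounds, both groups are carbon only, so it remains open whether an amine or a carboxylic acid at this position would keep the number. Also open, on these data alone, is whether a shorter chain, such as methyl, would do the same.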